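The compounds below may be only part of what the source reports. "The series", "measured", "known", "first", "only" and "open" are said of these compounds alone.

Measured in a functional assay on HEL cells (Homo sapiens) for cytotoxicity; on this read-out lower numbers stand for higher toxicity in this test and higher numbers for lower toxicity in this test:
compound 1 `O=c1[nH]c(=O)n([C@H]2C[C@H](O)[C@@H](CO)O2)cc1C#CCCCCCCCCCCl`: 74000 nM
compound 2 `O=c1[nH]c(=O)n([C@H]2C[C@H](O)[C@@H](CO)O2)cc1C#CCCCCCCCCCI`: 68000 nM
compound 3 `O=c1nc2oc(CCCCCCCCCF)cc2cn1[C@H]1C[C@H](O)[C@@H](CO)O1`: 200000 nM

Compound 3 shows the highest number of the three; its nearest neighbour is compound 1, and compound 2 lies furthest from it. Compound 4 `O=c1nc2oc(CCCCCCCCCBr)cc2cn1[C@H]1C[C@H](O)[C@@H](CO)O1` is not yet measured in this assay. It differs from compound 3 by bromo in place of fluoro on a saturated chain carbon, nine bonds along the chain from an aromatic carbon. Among the measured compounds shown here, the one measured step of comparable kind, a halogen swap on a saturated chain carbon nine bonds along the chain from a triple-bonded carbon, is a 1.1-fold lower number from compound 1 to compound 2 (0.04 log units; within the scatter). On that basis no step beyond the scatter is expected from compound 3 to compound 4 in this assay, with the caveat that the halogen pair and the core differ. Compound 4 is therefore estimated at 180000 nM, within 80000 nM to 400000 nM, an expected step of a 1.1-fold lower number from compound 3 to compound 4 (0.05 log units; within the scatter).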

Compound 4, half-maximal cytotoxic concentration: > 50000 nM
Compound 4 ended at the assay's limit; the forecaster's own chance of this, stated with the estimate: 25%; the middle value does not contradict the limit.
By their numbers in this assay, from the lowest: compounds 2 and 1 (each within the scatter of the next); then compound 3.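

In this assay compound 4 gives > 50000 nM, a limit and not a number. The step from compound 3 to compound 4 therefore cannot be read: the limit of > 50000 nM in this assay, at which 1 of the 4 values shown sits.

The compounds shown leave open whether bromo in place of fluoro on this chain changes the read-out in this assay at all.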